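The compounds below may be only part of what the source reports. "The series", "measured", "known", "first", "only" and "open" are said of these compounds alone.

Compound 1 `COC/C1=C/C[C@](C)(CCC=C(C)C)/C=C/[C@@H](OC(=O)C=C(C)C)[C@](C)(O)/C=C/C1=O`: 3950 nM
Compound 2 `CC(C)=CCC[C@]1(C)/C=C/[C@@H](OC(=O)C=C(C)C)[C@](C)(O)/C=C/C(=O)/C(CN2CCCC2)=C\C1`: 180 nM

In a functional assay on A549 cells (Homo sapiens) for antiproliferative activity, read by MTT assay, with a stated time of 48 h (a higher number here means a weaker inhibitor, a lower number a stronger inhibitor), compound 2 has the lower of the two numbers, at 180 nM. Compound 3 `CO/N=C/C1=C/C[C@](C)(CCC=C(C)C)/C=C/[C@@H](OC(=O)C=C(C)C)[C@](C)(O)/C=C/C1=O` is reached from compound 2 by one change: a group of 4 heavy atoms (2 carbon, 1 nitrogen, 1 oxygen; no ring) in place of a group of 6 heavy atoms (5 carbon, 1 nitrogen; one five-membered non-aromatic ring with 1 hetero atom), on a double-bonded ring carbon. Within the data shown here, only one measured step bears on this change, a 22-fold lower number from compound 1 to compound 2 (1.34 log units; beyond the scatter), a large step beyond the scatter in which pyrrolidin-1-yl took the place of methoxy. Compound 3 also has no pyrrolidin-1-yl group, as is true of compound 1 at 3950 nM, so a large step to a higher number is expected in this assay. Among the measured compounds shown here, no measured compound carries the entering group, so the size of the step remains uncertain. The step expected is an 11-fold higher number from compound 2 to compound 3 (1.05 log units; beyond the scatter). For compound 3 the estimated value is 2000 nM, with an expected range of 600 nM to 7000 nM.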

Compound 3, half-maximal inhibitory concentration: 3470 nM
The estimate for compound 3 lay 1.7-fold (0.24 log units) below the measured number; measured number inside the range.
By their numbers in this assay, from the lowest: compound 2; then compounds 3 and 1 (each within the scatter of the next).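

In this assay, compound 3 places a nitrogen at this double-bonded ring carbon, yet its open-chain group gives a 19-fold higher number from compound 2 to compound 3 (1.29 log units; beyond the scatter) as the (pyrrolidin-1-yl)methyl group leaves. The same group gives a 1.1-fold lower number from compound 1 to compound 3 (0.06 log units; within the scatter), so the two open-chain groups of compound 1 and compound 3 cannot be told apart here, and among the three compounds only the (pyrrolidin-1-yl)methyl group of compound 2 gives the low number. Nothing measured here accounts for this difference.

The compounds shown leave open whether a low number needs the five-membered ring itself or would also appear with an open-chain amine such as dimethylaminomethyl. They also leave open how a six-membered piperidin-1-ylmethyl or morpholin-4-ylmethyl group, or a carboxylic acid, would read at this carbon.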